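The compounds below may be only part of what the source reports. "The series", "measured", "known", "first", "only" and "open" are said of these compounds alone.

Three compounds with a shared theme give a starting picture. Compound 1 `CCCc1cccc(C[C@H](O)/C=C/[C@H]2CCC(=S)N2CCCCCCC(=O)O)c1` gives 27 nM in a functional assay on CHO cells for agonist activity at prostaglandin E2 receptor EP4 subtype (Rattus norvegicus), read by cAMP accumulation and immunoassay, with a stated time of 10 min; on this read-out higher numbers stand for an effect only at larger amounts of compound and lower numbers for an effect already at smaller amounts. Compound 2 `O=C(O)CCCSCCN1C(=O)OC[C@@H]1/C=C/[C@@H](O)Cc1cccc(C(F)(F)F)c1` gives 12 nM in this assay, and compound 3 `O=C(O)CCCSCCN1C(=O)SC[C@@H]1/C=C/[C@@H](O)Cc1ccccc1` gives 4.8 nM in this assay. Compound 3 therefore stands at the lowest of the three numbers: the gap to compound 2 and the larger gap to compound 1 both lie beyond the usual scatter, so compound 3 is the most potent of the three measured compounds.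

Compound 4 `CCCc1cccc(C[C@H](O)/C=C/[C@H]2CSC(=O)N2CCSCCCC(=O)O)c1` keeps the core of compound 3 and adds one change on the aromatic ring: propyl in place of hydrogen on an aromatic carbon. Among the compounds with values here, no measured pair in this set shows this single change on its own, so its effect cannot be read directly from any measured step. Compound 1 carries the same propyl group, but on a different core, and its number alone says nothing about the change in isolation. The step from compound 3 to compound 4 is expected to stay small, within or near the scatter, as a 1.3-fold higher number from compound 3 to compound 4 (0.10 log units; within the scatter). For compound 4 the expected value in this assay is 6 nM, with a range from 1.5 nM to 25 nM.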

Compound 4, half-maximal effective concentration: 6.1 nM
Estimate against measurement, compound 4: 1.0-fold (0.01 log units) below; the measured number falls inside the stated range.
By their numbers in this assay, from the lowest: compounds 3, 4 and 2 (each within the scatter of the next, the first and the last beyond it); then compound 1.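

Within the data shown here, compound 4 gives the first direct reading of one change on one core: in this assay, propyl in place of hydrogen on an aromatic carbon, meta to a large group, gives a step that stays within the usual scatter (a 1.3-fold higher number from compound 3 to compound 4 (0.10 log units; within the scatter)). Compound 1 also carries propyl, but its different core could not show this. The ring therefore accepts this added chain at this place with no change in the number that can be told from the scatter, though nothing here offers an explanation for that result.

On these data alone, whether a longer chain such as hexyl, a shorter one such as methyl, or an amine at this same place would also leave the number within the scatter remains open. So does whether propyl at another place on the ring would behave in the same way.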